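Chloro in Place of Isopropyl: Expectation Before Measurement

This account rests on a few compounds, and the source may have more. Where it says the series, first, only, none or still open, it means among the compounds named here.

Among the compounds with values here, compound 1 `C=C1C(=O)OC[C@H]1CCOC(=O)Nc1ccc(C(C)C)cc1` gives 12400 nM in an ADME assay on RAW264.7 cells (Mus musculus) for cytotoxicity, read by MTT assay, with a stated time of 18 h (on this read-out higher numbers stand for lower toxicity in this test and lower numbers for higher toxicity in this test), the lowest of the three numbers known so far. Its nearest neighbour, compound 2 `C=C1C(=O)OC[C@@H]1CCOC(=O)Nc1ccc(C(C)C)cc1`, gives 15300 nM in this assay. a 1.2-fold higher number from compound 1 to compound 2 (0.09 log units; within the scatter), a result consistent with the fact that compounds 1 and 2 differ only in the configuration as drawn. Compound 3 `C=C1C(=O)OC[C@@H]1CCOC(=O)Nc1ccccc1F` gives 24200 nM, and the values of compound 1 and compound 3 lie within the scatter of each other. Compound 4 `C=C1C(=O)OC[C@H]1CCOC(=O)Nc1ccc(Cl)cc1` arises from compound 1 by chloro in place of isopropyl on an aromatic carbon. Within the data shown here, no measured step touches the group on the aromatic ring; the only measured step, the one between stereoisomers, stayed within the scatter. Compound 4 is therefore expected to show no change beyond the scatter, a 1.2-fold higher number from compound 1 to compound 4 (0.08 log units; within the scatter). The estimate for compound 4 is 15000 nM, with a range from 6000 nM to 40000 nM.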

Compound 4, half-maximal cytotoxic concentration: 9140 nM
For compound 4 the middle estimate is 1.6-fold (0.22 log units) above the measured one; the range from low to high includes it.
By their numbers in this assay, from the lowest: compounds 4, 1, 2 and 3 (each within the scatter of the next, the first and the last beyond it).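

In this assay, replacing isopropyl with chloro on the aromatic carbon gives a 1.4-fold lower number from compound 1 to compound 4 (0.13 log units; within the scatter), so this position now has a measured substitution, and swapping these two groups leaves the number within the scatter. The step spans a change from 3 heavy atoms to 1 heavy atom, neither group having hydrogen-bond donors or acceptors. Nothing at hand bears on why the number holds at this position. Going by these compounds, whether an amine, a carboxylic acid or a longer chain at this position would also stay within the scatter remains open. So does the effect of chloro combined with the opposite configuration at the saturated ring carbon.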